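Swapping the aryl group on the ether for a 2-methylphenyl

The source may report more compounds than this note shows. Statements on the series, on what has been measured and on what is new or still open speak of the compounds shown alone.

Of the compounds shown here, three sharing one core have been measured in a functional assay on CHO cells for agonist activity at Free fatty acid receptor 1 (Homo sapiens), read by FLIPR and calcium flux, tested at 1 uM; on this read-out higher numbers stand for an effect only at larger amounts of compound and lower numbers for an effect already at smaller amounts. Compound 1 `Cc1ccc(OCc2nnc(C(=O)Nc3ccc(CCC(=O)O)cc3)s2)cc1C` gives 1130 nM. Compound 2 `Cc1ccc(OCc2nnc(C(=O)Nc3ccc(CCC(=O)O)cc3)s2)c(C)c1` gives 2540 nM. Compound 3 `O=C(O)CCc1ccc(NC(=O)c2nnc(COc3cccc(C(F)(F)F)c3)s2)cc1` gives 3090 nM, the highest of the three numbers; its gap to compound 2 lies within the scatter, while the step of a 2.7-fold higher number from compound 1 to compound 3 (0.44 log units; beyond the scatter) lies beyond it. Changing the aryl group on the oxygen has so far moved the numbers only modestly: a 2.2-fold higher number from compound 1 to compound 2 (0.35 log units; beyond the scatter) and a 1.2-fold higher number from compound 2 to compound 3 (0.09 log units; within the scatter).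

Compound 4 `Cc1ccccc1OCc1nnc(C(=O)Nc2ccc(CCC(=O)O)cc2)s1` is not yet measured. It differs from compound 3 in one place: 2-methylphenyl in place of 3-(trifluoromethyl)phenyl on an oxygen on a saturated carbon. Among the compounds with values here, two measured steps bear on this change, both varying the same aryl group. Compound 2, which also carries a methyl on the carbon next to the ether attachment point of the ring, sits close to compound 3, and compound 1 sits only modestly lower. Within the data shown here, no measured step removes a methyl outright, so the direction is uncertain. Compound 4 is therefore expected to stay near compound 3, with a step of about a 1.0-fold lower number from compound 3 to compound 4 (0.01 log units; within the scatter) in this assay, which lies within the scatter. The estimate for compound 4 is 3000 nM, with a range from 1200 nM to 8000 nM.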

Compound 4, half-maximal effective concentration: 1520 nM
Compound 4: the middle estimate sits 2.0-fold (0.30 log units) above what was measured; measured number inside the range.
By their numbers in this assay, from the lowest: compounds 1, 4, 2 and 3 (each within the scatter of the next, the first and the last beyond it).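

In this assay the 2-methylphenyl in place of the 3-(trifluoromethyl)phenyl on the oxygen gives a 2.0-fold lower number from compound 3 to compound 4 (0.31 log units; beyond the scatter) so this change at this position has a modest but real effect on the number, even though the earlier swap from the 2,4-dimethylphenyl to the 3-(trifluoromethyl)phenyl did not. Within the data shown here, this is also the first step that takes a methyl away outright: hydrogen in place of methyl on an aromatic carbon gives a 1.7-fold lower number from compound 2 to compound 4 (0.22 log units; within the scatter) and the comparison with the 3,4-dimethylphenyl gives a 1.3-fold higher number from compound 1 to compound 4 (0.13 log units; within the scatter) so the ring with one methyl cannot be told apart from either ring with two. Nothing measured here gives a reason for these differences.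

The compounds shown carry only methyl and trifluoromethyl on this aryl ring, which leaves open how a plain phenyl, a 2-chlorophenyl or a 2-methoxyphenyl on the oxygen would compare in this assay and whether any of them would move the number by more than a modest step. Also open, as far as these compounds go, is whether these small differences would hold with a tetrazole in place of the carboxylic acid.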